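A few compounds are considered here, and "the series" means these few. Any claim that something is new, unique, unknown or untested is made for them only; others in the source may bear on it.

Measured in a functional assay on MDA-MB-231 cells (Homo sapiens) for cytotoxicity, read by ELISA, with a stated time of 2 days; on this read-out higher numbers stand for weaker inhibition and lower numbers for stronger inhibition:
- compound 1 `Oc1ccc(-c2cc(-c3ccccc3)cc(-c3cccs3)n2)cc1`: 2400 nM
- compound 2 `Oc1ccc(-c2cc(-c3ccccc3)cc(-c3ccco3)n2)cc1`: 1400 nM
- compound 3 `Oc1ccc(-c2cc(-c3ccccc3)cc(-c3cccnc3)n2)cc1`: 2200 nM

Compound 3 cannot be separated from the other two on these numbers: a 1.1-fold lower number from compound 1 to compound 3 (0.04 log units; within the scatter) and a 1.6-fold higher number from compound 2 to compound 3 (0.20 log units; within the scatter) both lie within the scatter, as does a 1.7-fold lower number from compound 1 to compound 2 (0.23 log units; within the scatter).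

The next change leads to compound 4 `Oc1ccc(-c2cc(-c3ccccc3)cc(-c3ccc(O)cc3)n2)cc1`, with 4-hydroxyphenyl in place of pyridin-3-yl on an aromatic carbon. Among the measured compounds shown here, no measured step introduces 4-hydroxyphenyl, so the three swaps among thiophen-2-yl, furan-2-yl and pyridin-3-yl bear on it only indirectly. With those steps this small, no step beyond the scatter is expected in this assay, and neither direction is favoured. The expected step is a 1.1-fold lower number from compound 3 to compound 4 (0.04 log units; within the scatter). Compound 4 is estimated at 2000 nM, with an expected range of 700 nM to 6000 nM.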

Compound 4, half-maximal inhibitory concentration: 6700 nM
The estimate for compound 4 lay 3.4-fold (0.53 log units) below the measured number; the measured number lies above the stated range.
By their numbers in this assay, from the lowest: compounds 2, 3 and 1 (each within the scatter of the next); then compound 4.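

In this assay, the position next to the ring nitrogen gives its first steps beyond the scatter with 4-hydroxyphenyl: a 3.0-fold higher number from compound 3 to compound 4 (0.48 log units; beyond the scatter), a 4.8-fold higher number from compound 2 to compound 4 (0.68 log units; beyond the scatter) and a 2.8-fold higher number from compound 1 to compound 4 (0.45 log units; beyond the scatter). The substituent here therefore does affect the read-out, although thiophen-2-yl, furan-2-yl and pyridin-3-yl could not be separated. No measurement on hand identifies which feature of the change accounts for these steps.

On these data alone, it remains open whether the hydroxyl or the carbon-only ring carries the change. A 4-methoxyphenyl or 4-aminophenyl group at this position would bear on that.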